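Butyl to cyclopentyl: an expected drop in growth inhibition

A few compounds are considered here, and "the series" means these few. Any claim that something is new, unique, unknown or untested is made for them only; others in the source may bear on it.

Compound 1 `CCCCn1cnc2c(Nc3cccc(Cl)c3)nc(NCOCc3ccc(/C=C/C(=O)Nc4ccccc4N)cc3)nc21` gives 30.4% in a functional assay on HepG2 cells (Homo sapiens) for antiproliferative activity, read by CCK-8 assay, with a stated time of 72 h, tested at 8 uM; on this read-out higher numbers stand for a stronger effect at the one concentration tested and lower numbers for a weaker effect.
Compound 2 `Nc1ccccc1NC(=O)/C=C/c1ccc(COCNc2nc(Nc3cccc(Cl)c3)c3ncn(C4CCCC4)c3n2)cc1` gives 14.8%.
Compound 3 `CCCCn1cnc2c(Nc3ccccc3)nc(NCOCc3ccc(/C=C/C(=O)Nc4ccccc4N)cc3)nc21` gives 59.3%.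

The three measured compounds share one core and differ in two places. One change is cyclopentyl in place of butyl on an aromatic nitrogen, and it produced a number 15.6 percentage points lower from compound 1 to compound 2 (beyond the scatter). The other change is hydrogen in place of chloro on an aromatic carbon, which produced a number 28.9 percentage points higher from compound 1 to compound 3 (beyond the scatter), so compound 3 stands highest of the three.

Compound 4 `Nc1ccccc1NC(=O)/C=C/c1ccc(COCNc2nc(Nc3ccccc3)c3ncn(C4CCCC4)c3n2)cc1` has not yet been measured. It differs from compound 3 by cyclopentyl in place of butyl on an aromatic nitrogen, the same change as that between compound 1 and compound 2, made on the core of compound 3 rather than the core of compound 1. In this assay the expected step is a number 15.3 percentage points lower from compound 3 to compound 4 (beyond the scatter), resting on a number 15.6 percentage points lower from compound 1 to compound 2 (beyond the scatter). Compound 4 is therefore estimated at 44%, expected to fall between 28% and 58%.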

Compound 4, a percentage reported as inhibition, at one concentration (the size of the read-out at that concentration, not a potency): 18.8%
Compound 4: middle estimate off by 25.2 percentage points, on the high side, and the stated range ends above it.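

In this assay, cyclopentyl in place of butyl gives a number 40.5 percentage points lower from compound 3 to compound 4 (beyond the scatter), so the direction seen before holds but its size does not carry over: the same change on two cores in this assay, a number 15.6 percentage points lower (beyond the scatter) from compound 1 to compound 2 and a number 40.5 percentage points lower (beyond the scatter) from compound 3 to compound 4, 24.9 percentage points apart, beyond the scatter of two such steps. Hydrogen in place of chloro gives a number 4 percentage points higher from compound 2 to compound 4 (within the scatter), so the gain seen with butyl is not repeated with cyclopentyl: the same change on two cores in this assay, a number 28.9 percentage points higher (beyond the scatter) from compound 1 to compound 3 and a number 4 percentage points higher (within the scatter) from compound 2 to compound 4, 24.9 percentage points apart, beyond the scatter of two such steps. The effect of each change therefore depends on the group in the other place, but this single set of four compounds does not show why, nor whether the same holds for other changes in the series.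

From the compounds shown here alone, it remains open whether a longer chain such as hexyl on the aromatic nitrogen would behave like butyl or like cyclopentyl. Going by these compounds, it is also open how fluoro or methoxy in place of chloro would compare.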